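Series notes: replacing the trimethylpyrazole in compound 3

The source may report more compounds than this note shows. Statements on the series, on what has been measured and on what is new or still open speak of the compounds shown alone.

Compound 3 `Cc1cc(C)c(-c2c(C)nn(C)c2C)cc1NC(=O)c1ccc(OCc2ccccn2)cc1` gives 122 mL.min-1.g-1 in an ADME assay on microsomes from liver (Homo sapiens) for metabolic stability (on this read-out higher numbers stand for fast clearance and lower numbers for slow clearance), the highest of the three measured numbers. Compound 1 `Cc1cc(C)c(-c2nc3ccccc3[nH]2)cc1NC(=O)c1ccc(OCc2ccccn2)cc1` gives 30 mL.min-1.g-1 and compound 2 `Cc1cc(C)c(-c2c[nH]nc2C)cc1NC(=O)c1ccc(OCc2ccccn2)cc1` gives 20 mL.min-1.g-1 in this assay. The step from compound 3 to compound 4 `Cc1cc(C)c(-c2cccc(N)n2)cc1NC(=O)c1ccc(OCc2ccccn2)cc1` is 6-aminopyridin-2-yl in place of 1,3,5-trimethyl-1H-pyrazol-4-yl on an aromatic carbon. Among the compounds with values here, the steps that bear on it are a 4.1-fold higher number from compound 1 to compound 3 (0.61 log units; beyond the scatter) and a 6.1-fold higher number from compound 2 to compound 3 (0.79 log units; beyond the scatter): both other groups at this position gave lower numbers than the trimethylpyrazole, while a 1.5-fold lower number from compound 1 to compound 2 (0.18 log units; within the scatter). Leaving the trimethylpyrazole is therefore expected to lower the number, with a step of a 3.5-fold lower number from compound 3 to compound 4 (0.54 log units; beyond the scatter) estimated. Compound 4 is expected to give about 35 mL.min-1.g-1 in this assay, likely between 15 mL.min-1.g-1 and 90 mL.min-1.g-1.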

Compound 4, intrinsic clearance in microsomes: 88 mL.min-1.g-1
The estimate for compound 4 lay 2.5-fold (0.40 log units) below the measured number; the range from low to high includes it.
By their numbers in this assay, from the lowest: compounds 2 and 1 (each within the scatter of the next); then compounds 4 and 3 (each within the scatter of the next).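

In this assay, a six-membered ring in place of the trimethylpyrazole gives no clear change: a 1.4-fold lower number from compound 3 to compound 4 (0.14 log units; within the scatter) stays within the scatter, so leaving 1,3,5-trimethyl-1H-pyrazol-4-yl does not by itself lower the number. Against the other two groups the steps lie beyond the scatter, with a 4.4-fold higher number from compound 2 to compound 4 (0.64 log units; beyond the scatter) and a 2.9-fold higher number from compound 1 to compound 4 (0.47 log units; beyond the scatter) leaving the low numbers with compound 1 and compound 2 only. Nothing available here accounts for these differences.

Open, as far as these compounds go, is what a plain pyridin-2-yl would give at this position, and so whether the amine of compound 4 has any bearing on its number.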